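A methylsulfonylphenyl amide on the shared core

The source may hold more compounds than are shown below. What is called first, only, known or untested is meant among the compounds shown, and "the series" means these compounds.

Three amides on one shared core were tested in a functional assay on MCF7 cells (Homo sapiens) for antiproliferative activity, read by MTT assay, with a stated time of 72 h; on this read-out higher numbers stand for weaker inhibition and lower numbers for stronger inhibition. Compound 1 `O=C(Nc1ccc(Cl)c(-c2nnc3c(Cl)cccn23)c1)c1ccc(C(F)(F)F)cc1Cl` gives 81600 nM. For compound 2 `Cc1cc(Cl)ccc1C(=O)Nc1ccc(Cl)c(-c2nnc3c(Cl)cccn23)c1` the assay reports only a limit, > 100000 nM. For compound 3 `CS(=O)(=O)c1ccc(C(=O)Nc2ccc(Cl)c(-c3nnc4c(Cl)cccn34)c2)c(Cl)c1` it likewise reports a limit, > 100000 nM. For the measured compounds named here, the one step between measured compounds, an at least 1.2-fold higher number from compound 1 to compound 3 (0.08 log units; that floor lies within the scatter), puts methylsulfonyl in place of trifluoromethyl, and its floor rests on (the limit of > 100000 nM in this assay, at which 2 of the 3 values shown sit). Compound 2 thus stands at the limit, beyond every number shown. Compound 3, which also carries a methylsulfonyl group, stands at the limit too. Compound 4 `CS(=O)(=O)c1cccc(C(=O)Nc2ccc(Cl)c(-c3nnc4c(Cl)cccn34)c2)c1` carries 3-(methylsulfonyl)phenyl in place of 4-chloro-2-methylphenyl on a carbonyl carbon. Compound 4 is expected to show a step that the limit leaves unreadable from compound 2 to compound 4, most likely returning a limit once more. Compound 4 is estimated at 120000 nM, between 50000 nM and 300000 nM.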

Compound 4, half-maximal inhibitory concentration: 88900 nM
Compound 4: the middle estimate sits 1.3-fold (0.13 log units) above what was measured; the range from low to high includes it.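

In this assay, 3-(methylsulfonyl)phenyl on the carbonyl carbon gives compound 4 a measured number, where 4-chloro-2-methylphenyl leaves compound 2 at a limit. The change brings an at least 1.1-fold lower number from compound 2 to compound 4 (0.05 log units; that floor lies within the scatter), and the true size of the step cannot be read, since its floor rests on a limit: the limit of > 100000 nM in this assay, at which 2 of the 4 values shown sit.

The compounds shown leave open whether an amine or a carboxylic acid in place of the methylsulfonyl group of compound 4 would shift the number beyond the usual scatter. They also leave open what a longer chain on the sulfonyl sulfur would do.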